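Two Long-Chain Lactones at the Limit, and a Third

The source may report more compounds than this note shows. Statements on the series, on what has been measured and on what is new or still open speak of the compounds shown alone.

Compound 1 `COCCCCCCCCCCC/C=C1\CC(CO)(COC(=O)C(C)(C)C)OC1=O` and compound 2 `COC(=O)CCCCCCCCCCCCCC/C=C1\CC(CO)(COC(=O)C(C)(C)C)OC1=O` share a lactone core and differ only in the tail of the long chain. In a functional assay on NCI-H322 cells (Homo sapiens) for antiproliferative activity (a higher number here means a weaker inhibitor of growth, a lower number a stronger inhibitor of growth), compound 1 gives > 10 ug/mL, which is a limit of the assay and not a number. In this assay compound 2 likewise gives > 10 ug/mL, again a limit rather than a measured number. The step that the two limits leave unreadable from compound 1 to compound 2 therefore cannot be read, and the limit of > 10 ug/mL in this assay, at which 2 of the 2 values shown sit, shows that both values stop at the same limit.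

Compound 3 `CC(=O)NCCCCCCCCCCCCCCC/C=C1\CC(CO)(COC(=O)C(C)(C)C)OC1=O` carries the difference (acetamidomethyl in place of methoxycarbonyl on a saturated chain carbon, ten or more bonds along the chain from a double-bonded chain carbon). Within the data shown here, no measured step bears on this change, since the only step available is unreadable. The expectation for compound 3 is therefore that this assay again reports a value near or at the limit, and the estimated step that the limit leaves unreadable from compound 2 to compound 3 is taken as none beyond the scatter. Compound 3 is thus expected to give about 15 ug/mL, within an estimated range from 5 ug/mL to 50 ug/mL, with a fair chance that only a limit is reported.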

Compound 3, concentration for 50% growth inhibition: > 10 ug/mL
Compound 3 ended at the assay's limit (the forecaster's own chance of this, stated with the estimate: 70%); the middle value is on the limit's open side.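

In this assay compound 3 gives > 10 ug/mL, a limit of the assay and not a number. No step among compound 1, compound 2 and compound 3 can be read, since all three stop at the same limit: the limit of > 10 ug/mL in this assay, at which 3 of the 3 values shown sit.

The compounds shown leave open whether any change in the tail of the long chain alters growth inhibition in this assay.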